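Compound 1 to compound 4: replacing the isobutoxy group

The source may report more compounds than this note shows. Statements on the series, on what has been measured and on what is new or still open speak of the compounds shown alone.

Compound 1 `CC(C)COC(=O)N1CCCc2cc(S(=O)(=O)N3CC(c4ccccc4)NC3=O)ccc21`: > 20000 nM (a limit)
Compound 2 `CCCCOC(=O)N1CCCc2cc(S(=O)(=O)N3CC(c4ccccc4)NC3=O)ccc21`: > 20000 nM (a limit)
Compound 3 `C=CCOC(=O)N1CCCc2cc(S(=O)(=O)N3CC(c4ccccc4)NC3=O)ccc21`: 4310 nM

In a functional assay on A549 cells (Homo sapiens) for antiproliferative activity, read by MTT assay (on this read-out lower numbers stand for stronger inhibition and higher numbers for weaker inhibition), compound 1 gives > 20000 nM, which is a limit and not a number. Its place on the scale is therefore (the limit of > 20000 nM in this assay, at which 2 of the 3 values shown sit).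

Compound 4 `O=C1NC(c2ccccc2)CN1S(=O)(=O)c1ccc2c(c1)CCCN2C(=O)C(F)(F)F` carries trifluoromethyl in place of isobutoxy on a carbonyl carbon.

Going by the values given here, no measured step makes this exchange, so the evidence is indirect. The step that the two limits leave unreadable from compound 1 to compound 2 gives no size. The steps of an at least 4.6-fold lower number from compound 1 to compound 3 (0.66 log units; beyond the scatter) and an at least 4.6-fold lower number from compound 2 to compound 3 (0.66 log units; beyond the scatter) show that a change in this part of the molecule can move the number beyond the scatter. On the strength of the step to compound 3 with its 4310 nM, a modest move to a lower number is expected from compound 1. Another limit remains quite possible for compound 4.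

For compound 4 the expected value is 9000 nM, with an estimated range of 2500 nM to 30000 nM.

The estimated step is an at least 2.2-fold lower number from compound 1 to compound 4 (0.34 log units; beyond the scatter).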

Compound 4, half-maximal inhibitory concentration: > 20000 nM
Compound 4: no number, only a limit; the forecaster's own chance of this, stated with the estimate: 40%; middle value at least 2.2-fold (0.34 log units) from the limit.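

In this assay compound 4 gives only a limit and not a number, which puts it at the same place on the scale as the two alkoxy compounds that also reach it: the limit of > 20000 nM in this assay, at which 3 of the 4 values shown sit.

The steps to compound 4 from compound 1 and from compound 2 cannot be read, since both ends of each are limits. Going by these compounds alone, the one readable step is an at least 4.6-fold higher number from compound 3 to compound 4 (0.66 log units; beyond the scatter), so trifluoromethyl on this carbonyl carbon does not keep the measurable activity of the allyloxy compound, and among the four compounds only compound 3 gives a number, 4310 nM.

From the compounds shown here alone, whether that number depends on the double bond of the allyloxy group, or could be matched or bettered by a propargyloxy or benzyloxy group, stays open. So does the effect of an amine on this carbonyl carbon, and the order of compound 1, compound 2 and compound 4 cannot be told from their limits.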